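This account rests on a few compounds, and the source may have more. Where it says the series, first, only, none or still open, it means among the compounds named here.

Working notes on the series. In a functional assay on M21 cells (Homo sapiens) for antiproliferative activity, read by sulforhodamine B assay, with a stated time of 48 h (a lower number here means a stronger inhibitor, a higher number a weaker inhibitor), compound 1 `CCCN1CCN(c2ccc(S(=O)(=O)Oc3ccccc3C)cc2)C1=O` returns only a limit, > 100000 nM. Compound 2 `CCCN1CCN(c2ccc(S(=O)(=O)Oc3ccc(C)cc3C)cc2)C1=O` gives 9700 nM. Compound 3 `CCCN1CCN(c2ccc(S(=O)(=O)Oc3cccc(F)c3)cc2)C1=O` gives 12000 nM, which places it level with compound 2: the gap is a 1.2-fold higher number from compound 2 to compound 3 (0.09 log units; within the scatter). Both separate clearly from compound 1, with an at least 10-fold lower number from compound 1 to compound 2 (1.01 log units; beyond the scatter) and an at least 8.3-fold lower number from compound 1 to compound 3 (0.92 log units; beyond the scatter).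

Compound 4 `CCCN1CCN(c2ccc(S(=O)(=O)Oc3cccc([N+](=O)[O-])c3)cc2)C1=O` departs from compound 3 at a single place: nitro in place of fluoro on an aromatic carbon, meta to a large group, the change from 3-fluorophenyl to 3-nitrophenyl (nitro in place of fluoro on an aromatic carbon). Among the compounds with values here, no measured step exchanges this substituent directly. The closest evidence comes from replacing the whole group on the oxygen. That replacement gave a 1.2-fold higher number from compound 2 to compound 3 (0.09 log units; within the scatter) in one case and an at least 8.3-fold lower number from compound 1 to compound 3 (0.92 log units; beyond the scatter) in the other, so the two available precedents disagree in size. Compounds 2 and 3 carry different groups there yet sit together, and this favours no large move. The expected change is a 1.1-fold lower number from compound 3 to compound 4 (0.04 log units; within the scatter), which means no step beyond the scatter in either direction. The upper end stays wide, since an at least 8.3-fold lower number from compound 1 to compound 3 (0.92 log units; beyond the scatter) shows how far a change on this oxygen can carry the number. For compound 4 the estimated value is 11000 nM, with an expected range from 3500 nM to 40000 nM.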

Compound 4, half-maximal inhibitory concentration: 38000 nM
The estimate for compound 4 lay 3.5-fold (0.54 log units) below the measured number, within the range that was stated.
By their numbers in this assay, from the lowest: compounds 2 and 3 (each within the scatter of the next); then compound 4. At a limit, above all of these: compound 1.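

Within the data shown here, at this place on the aromatic ring, meta to a large group, the exchange of one substituent is not neutral in this assay: nitro in place of fluoro gives a 3.2-fold higher number from compound 3 to compound 4 (0.50 log units; beyond the scatter), a step beyond the scatter, where the earlier compounds offered only replacements of the whole group on the oxygen. The 3-nitrophenyl group also separates from the 2,4-dimethylphenyl group, with a 3.9-fold higher number from compound 2 to compound 4 (0.59 log units; beyond the scatter), so the level reading shared by compound 2 and compound 3 does not extend to every group on this oxygen. Compound 4 still keeps a measured number, with an at least 2.6-fold lower number from compound 1 to compound 4 (0.42 log units; beyond the scatter), but that step is only a bound, as compound 1 stands at a limit of the assay: the limit of > 100000 nM in this assay, at which 1 of the 4 values shown sits.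

With only fluoro and nitro compared at this place, no trend can be drawn and nothing shown explains the step; an amine, a carboxylic acid or a methoxy group on the same carbon would show whether the change is particular to nitro. Also open, as far as these compounds go, is whether the step from fluoro to nitro would hold with a longer chain in place of the propyl chain on the shared core.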